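The compounds below may be only part of what the source reports. "The series", "measured", "known", "first", "only" and "open" are said of these compounds alone.

Compound 3, `CC1=CC[C@H](C(C)(C)NC(=S)N/N=C/c2ccc(F)cc2)CC1`, gives in a functional assay on K562 cells (Homo sapiens) for inhibition, read by sulforhodamine B assay, with a stated time of 48 h (a higher number here means a weaker inhibitor of growth, a lower number a stronger inhibitor of growth), only a limit, > 100000 nM. Compound 1, `CC1=CC[C@H](C(C)(C)NC(=S)N/N=C/c2ccccc2)CC1`, gives 47600 nM in this assay, and compound 2, `COc1ccc(/C=N/NC(=S)NC(C)(C)[C@H]2CC=C(C)CC2)cc1`, gives 30700 nM. The step of a 1.6-fold lower number from compound 1 to compound 2 (0.19 log units; within the scatter) lies within the scatter, while an at least 2.1-fold higher number from compound 1 to compound 3 (0.32 log units; beyond the scatter) and an at least 3.2-fold higher number from compound 2 to compound 3 (0.51 log units; beyond the scatter) both weaken growth inhibition. Compound 4, `CC1=CC[C@H](C(C)(C)NC(=S)N/N=C/c2ccc(Cl)cc2)CC1`, differs from compound 3 by chloro in place of fluoro on an aromatic carbon. Going by the values given here, no measured step swaps one halogen for another, so the only guide is that fluoro sat at the limit. Compound 4 is therefore expected to stay near that limit, with a number no higher from compound 3 to compound 4 (the limit leaves the size open) reflecting no change beyond the scatter. Compound 4 is estimated at 100000 nM, within 40000 nM to 250000 nM.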

Compound 4, concentration for total growth inhibition: 16900 nM
For compound 4 the middle estimate is 5.9-fold (0.77 log units) above the measured one, and the stated range ends above it.
By their numbers in this assay, from the lowest: compounds 4, 2 and 1 (each within the scatter of the next, the first and the last beyond it). At a limit, above all of these: compound 3.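

At this place, on an aromatic carbon para to a large group, the choice of halogen matters in this assay: an at least 5.9-fold lower number from compound 3 to compound 4 (0.77 log units; beyond the scatter). Chloro also stands apart from hydrogen at this place, a 2.8-fold lower number from compound 1 to compound 4 (0.45 log units; beyond the scatter), but not from methoxy, a 1.8-fold lower number from compound 2 to compound 4 (0.26 log units; within the scatter). The value of compound 3 is a limit, so the full size of the change from 4-fluorophenyl to 4-chlorophenyl stays unknown: the limit of > 100000 nM in this assay, at which 1 of the 4 values shown sits.

The compounds shown leave open whether bromo would follow chloro or fluoro at this place. They also leave open how an amine or a carboxylic acid there would compare.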